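The source may hold more compounds than are shown below. What is called first, only, known or untested is meant among the compounds shown, and "the series" means these compounds.

Measured so far:
compound 1 `NS(=O)(=O)c1ccc(-n2nc(-c3ccccc3)cc2-c2ccc3cc(F)ccc3n2)cc1`: 89.2%
compound 2 `NS(=O)(=O)c1ccc(-n2nc(-c3ccc(F)cc3)cc2-c2ccc3cc(F)ccc3n2)cc1`: 91.1%

In an ADME assay on Huh-7 cells (Homo sapiens) for cytotoxicity, read by XTT assay, with a stated time of 3 days, tested at 20 uM (on this read-out lower numbers stand for a stronger effect and higher numbers for a weaker effect at the one concentration tested), compound 1 gives 89.2%, and in this assay compound 2 gives 91.1%. The two numbers sit within the scatter of each other: the step of a number 1.9 percentage points higher from compound 1 to compound 2 (within the scatter), fluoro in place of hydrogen on an aromatic carbon, shows no effect that can be told from repeat-to-repeat variation. Compound 2 therefore stands at the same level as compound 1, with nothing in the series set apart from it.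

Next in the series is compound 3 `COc1ccc(-c2cc(-c3ccc4cc(F)ccc4n3)n(-c3ccc(S(N)(=O)=O)cc3)n2)cc1`. Relative to compound 2 the change is methoxy in place of fluoro on an aromatic carbon. Going by the values given here, no measured step touches a methoxy group; the only step in hand, a number 1.9 percentage points higher from compound 1 to compound 2 (within the scatter), concerns a different exchange at the same aromatic carbon and was within the scatter. Among the compounds with values here, both measured compounds give weak read-outs near the upper end of the scale, and with no step of size anywhere the expectation for compound 3 is a step of a number 3.1 percentage points lower from compound 2 to compound 3 (within the scatter), that is none beyond the scatter. Compound 3 is thus estimated at 88%, in the range 72% to 100%.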

Compound 3, a percentage reported as activity, at one concentration (the size of the read-out at that concentration, not a potency): 83.7%
Estimate against measurement, compound 3: 4.3 percentage points above, within the range that was stated.
By their numbers in this assay, from the lowest: compounds 3, 1 and 2 (each within the scatter of the next).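

At the aromatic carbon para to a large group, this assay now covers a third substituent: the exchange of 4-fluorophenyl for 4-methoxyphenyl gives a number 7.4 percentage points lower from compound 2 to compound 3 (within the scatter) and methoxy in place of hydrogen gives a number 5.5 percentage points lower from compound 1 to compound 3 (within the scatter) with neither step distinguishable from repeat-to-repeat variation. Hydrogen, fluoro and methoxy at this carbon are therefore not separated by this read-out, and the absence of a measurable step, earlier seen for fluoro alone, now also holds for a group that carries a hydrogen-bond acceptor. Nothing available bears on the reason for these numbers.

The compounds shown leave open whether a group of another kind at this carbon, such as an amine, a carboxylic acid or a longer alkoxy chain, would give a step beyond the scatter. Also open, as far as these compounds go, is whether the same flat picture holds when the fluoro on the shared core is exchanged or when the sulfonamide is replaced by a carboxylic acid, since every compound here keeps both groups unchanged.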